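The compounds below may be only part of what the source reports. "The series", "measured", "known", "first", "only" and "open" are said of these compounds alone.

Series notes. The shared core of compound 1 `CN1CCN(CCNCc2cn(-c3ccc(F)cc3F)nc2C2CCCCC2)CC1` carries a cyclohexyl group; compound 2 `CN1CCN(CCNCc2cn(-c3ccc(F)cc3F)nc2-c2ccc(Cl)cc2)CC1` and compound 3 `CN1CCN(CCNCc2cn(-c3ccc(F)cc3F)nc2-c2ccc(C(F)(F)F)cc2)CC1` carry a 4-chlorophenyl and a 4-(trifluoromethyl)phenyl in that place. In an ADME assay on Huh-7 cells (Homo sapiens) for cytotoxicity (on this read-out lower numbers stand for higher toxicity in this test and higher numbers for lower toxicity in this test), compound 1 gives only a limit of the assay, > 20000 nM. Compound 2 gives 19000 nM in this assay. Compound 3 gives 20000 nM in this assay, which sets it alongside compound 2: a 1.1-fold higher number from compound 2 to compound 3 (0.02 log units; within the scatter). The remaining steps are an at least 1.0-fold lower number from compound 1 to compound 2 (0.02 log units; that floor lies within the scatter) and a number no higher from compound 1 to compound 3 (the limit leaves the size open); with one value sitting at the limit of > 20000 nM in this assay, at which 1 of the 3 values shown sits, none of the three steps leaves the scatter, so the aryl exchanges made so far show no readable effect on cytotoxicity in this assay.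

Compound 4 `CN1CCN(CCNCc2cn(-c3ccc(F)cc3F)nc2-c2cccc(N(C)C)c2)CC1` differs from compound 3 by 3-(dimethylamino)phenyl in place of 4-(trifluoromethyl)phenyl on an aromatic carbon. Among the measured compounds shown here, no measured step exchanges a trifluoromethyl for a dimethylamino, so the steps that bear on it are only a 1.1-fold higher number from compound 2 to compound 3 (0.02 log units; within the scatter) and a number no higher from compound 1 to compound 3 (the limit leaves the size open), both flat. A step of no more than the scatter is therefore expected, no change at the digits printed from compound 3 to compound 4 (within the scatter), in no fixed direction. Compound 4 is estimated to give 20000 nM in this assay, between 9000 nM and 40000 nM, with a fair chance that only a limit is reported.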

Compound 4, half-maximal cytotoxic concentration: > 20000 nM
Compound 4 ended at the assay's limit (the forecaster's own chance of this, stated with the estimate: 45%); the middle value sits exactly at the limit.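

A 3-(dimethylamino)phenyl placed on this aromatic carbon, a group with a nitrogen and a hydrogen-bond acceptor, where the 4-(trifluoromethyl)phenyl it replaces has no acceptor, gives a number no lower from compound 3 to compound 4 (the limit leaves the size open). In this assay compound 4 gives > 20000 nM, which is a limit of the assay and not a number. Among the compounds shown here, the one readable comparison is an at least 1.0-fold higher number from compound 2 to compound 4 (0.02 log units; that floor lies within the scatter), so this exchange, like the earlier aryl exchanges, shows no readable effect on cytotoxicity at this position. The size of that first step and the step to compound 4 from compound 1 cannot be read, because their values rest on limits: the limit of > 20000 nM in this assay, at which 2 of the 4 values shown sit.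

The compounds shown leave open whether any group at this position moves the number in this assay at all, since nothing here separates from the scatter. Also open, from the compounds shown here alone, is whether a carboxylic acid or a primary amine on the phenyl ring would lower the number, and whether a 4-(dimethylamino)phenyl would read differently from the 3-(dimethylamino)phenyl of compound 4.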